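The source may report more compounds than this note shows. Statements on the series, on what has been measured and on what is new or still open speak of the compounds shown alone.

Measured compounds in a functional assay on the whole organism for inhibition, with Rattus norvegicus as the target, with stated times of 1 h and 3.5 h, at a dose of 100 mg/kg by the oral route; on this read-out higher numbers stand for more inhibition at the one dose given (going by the name of the read-out) and lower numbers for less inhibition:
- compound 1 `Nc1ncc(-c2ccccc2)c(-c2ccncc2)n1` gives 48%
- compound 2 `Cc1cncnc1-c1ccncc1` gives 50%
- compound 3 `CC(C)(C)c1nc(N)ncc1-c1ccccc1` gives 46%

Compound 3 holds the lowest of the three numbers, but both gaps to the other two lie within the scatter, so the three stand level. Among the measured compounds shown here, the one step between compounds differing in a single place is a number 2 percentage points lower from compound 1 to compound 3 (within the scatter); it concerns an aromatic carbon, not the ring nitrogen.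

Compound 4 `CC(=O)Nc1ncc(-c2ccccc2)c(C(C)(C)C)n1` differs from compound 3 by acetyl in place of hydrogen on a nitrogen on an aromatic ring. For the measured compounds named here, no measured step touches this nitrogen, so no step bears directly on the change; the series so far shows every single change staying within the scatter. The step of a number 2 percentage points lower from compound 3 to compound 4 (within the scatter) in this assay is therefore expected to stay within the scatter. Compound 4 is estimated at 44%, within 22% to 62%.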

Compound 4, a percentage reported as inhibition, in the whole organism at one dose (the size of the read-out at that dose, not a potency): 29%
Estimate against measurement, compound 4: 15 percentage points above; low and high end bracket the measured number.
By their numbers in this assay, from the lowest: compound 4; then compounds 3, 1 and 2 (each within the scatter of the next).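

In this assay, among the compounds shown here, the amino to acetamido change gives a number 17 percentage points lower from compound 3 to compound 4 (beyond the scatter), the first single change to pass beyond the scatter. This nitrogen on an aromatic ring therefore responds to substitution, unlike the aromatic carbon of the earlier step, which stayed within the scatter. No evidence at hand bears on the reason for this drop.

As far as these compounds go, whether the drop is specific to acetyl or follows from any group on this nitrogen remains open; methyl or a longer acyl chain such as propanoyl would separate the two. Also open, from the compounds shown here alone, is whether acetyl has the same effect on the amino group of compound 1 , which carries pyridin-4-yl in place of tert-butyl.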